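The source may report more compounds than this note shows. Statements on the series, on what has been measured and on what is new or still open speak of the compounds shown alone.

Compound 1 `CC(C)(C)Cc1ccc2nc(N)sc2c1` gives > 10 mg/kg in a functional assay on the whole organism with Rattus norvegicus as the target (on this read-out lower numbers stand for an effect already at smaller amounts and higher numbers for an effect only at larger amounts of compound), which is a limit of the assay and not a number.
Compound 2 `CCCCCCCc1ccc2nc(N)sc2c1` gives > 10 mg/kg in this assay, also a limit and not a number.
Compound 3 `N=c1sc2cc(OC(F)(F)F)ccc2n1CC(N)=O` gives 7 mg/kg in this assay.

Compound 3 therefore stands as the only one of the three with an actual number in this assay; the other two sit at the limit of > 10 mg/kg in this assay, at which 2 of the 3 values shown sit, so nothing can be said about how far they lie from compound 3. Going by the values given here, no two of the measured compounds differ from each other in a single place, so there is no measured step from which the size of a change of this kind could be read.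

Compound 4 `CN(C)CCn1c(=N)sc2cc(OC(F)(F)F)ccc21` has not yet been measured in this assay. It differs from compound 3 in one place: (dimethylamino)methyl in place of carbamoyl on a saturated chain carbon bound to an aromatic nitrogen. Without a measured step to lean on, the expectation for compound 4 is a modest gain, a step of a 1.4-fold lower number from compound 3 to compound 4 (0.15 log units; within the scatter) that could still fall within the usual scatter. Compound 4 is thus expected to give about 5 mg/kg in this assay, with a likely range from 1.5 mg/kg to 15 mg/kg.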

Compound 4, dose for half-maximal effect: 2.3 mg/kg
Compound 4: middle estimate off by 2.2-fold (0.34 log units), on the high side; the measured number falls inside the stated range.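

The carbamoylmethyl group of compound 3 is not needed for an effect in this assay: with 2-(dimethylamino)ethyl in its place, the series gains its first readable step, a 3.0-fold lower number from compound 3 to compound 4 (0.48 log units; beyond the scatter), and this step lies beyond the usual scatter. It shows that this place, on a saturated chain carbon bound to an aromatic nitrogen, accepts a change from carbamoyl to a group with no hydrogen-bond donor, without loss of effect. Nothing measured here explains which part of this exchange accounts for the step.

From the compounds shown here alone, it remains open whether the amine itself matters, since a plain propyl chain, a carboxylic acid or a morpholine at this place would each test a different part of the change. Also open, going by these compounds, is how far the chain can grow, for instance to 3-(dimethylamino)propyl.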